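A few compounds are considered here, and "the series" means these few. Any claim that something is new, unique, unknown or untested is made for them only; others in the source may bear on it.

Compound 1 `CCOc1cc(C(C)(C)C)ccc1C1=NC(c2ccc(Cl)cc2)C(c2ccc(Cl)cc2)N1C(=O)N1CCN(CCCCCCCC(=O)NO)CC1` gives 7760 nM in a functional assay on NCI-H1299 cells (Homo sapiens) for antiproliferative activity, read by CCK-8 assay, with a stated time of 72 h; on this read-out higher numbers stand for weaker inhibition and lower numbers for stronger inhibition. Compound 2 `CCOc1cc(C(C)(C)C)ccc1C1=NC(c2ccc(Cl)cc2)C(c2ccc(Cl)cc2)N1C(=O)N1CCN(CCCCC(=O)NO)CC1` gives 12900 nM. Compound 3 `CCOc1cc(C(C)(C)C)ccc1C1=NC(c2ccc(Cl)cc2)C(c2ccc(Cl)cc2)N1C(=O)N1CCN(CCCCCC(=O)NO)CC1` awaits measurement.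

On the numbers shown, compound 2 holds the higher of the two, but its only comparison, a 1.7-fold higher number from compound 1 to compound 2 (0.22 log units; within the scatter), lies within the scatter, so the two compounds cannot be told apart. The change to compound 3 is (hydroxycarbamoyl)methyl in place of hydroxycarbamoyl on a saturated chain carbon, four bonds along the chain from an amine nitrogen in a ring. For the measured compounds named here, only that one step bears on this chain lengthening, and it was small, so no movement beyond the scatter is expected in this assay. Compound 3 is therefore expected to give about 10000 nM, between 5000 nM and 20000 nM. The expected step is a 1.3-fold lower number from compound 2 to compound 3 (0.11 log units; within the scatter).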

Compound 3, half-maximal inhibitory concentration: 9390 nM
Compound 3: the middle estimate sits 1.1-fold (0.03 log units) above what was measured; the measured number falls inside the stated range.
By their numbers in this assay, from the lowest: compounds 1, 3 and 2 (each within the scatter of the next).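

In this assay the added chain carbon gives a 1.4-fold lower number from compound 2 to compound 3 (0.14 log units; within the scatter) and the comparison with the longest chain gives a 1.2-fold higher number from compound 1 to compound 3 (0.08 log units; within the scatter) and so compound 3 cannot be told apart from either neighbour. Where the earlier pair covered only two chain lengths, three lengths at this position now show no step beyond the scatter. Nothing available here bears on why the chain length makes so little difference.

From the compounds shown here alone, it remains open whether a longer chain would move the number beyond the scatter. The same holds for a carboxylic acid in place of the hydroxycarbamoyl end group.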